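The source may hold more compounds than are shown below. What is called first, only, known or untested is meant among the compounds shown, and "the series" means these compounds.

Measured compounds:

Compound 1 `CS(=O)(=O)Nc1ccc2c(c1)S(=O)(=O)N=C(C1=C(O)C3CCCCC3N(Cc3ccc(F)cc3)C1=O)N2`. In an ADME assay on Huh-7 cells (Homo sapiens) for cytotoxicity, with a stated time of 72 h (a higher number here means that more compound is tolerated, a lower number that less compound is tolerated), compound 1 gives > 33000 nM, a limit and not a number.
Compound 2 `CS(=O)(=O)Nc1ccc2c(c1)S(=O)(=O)N=C(C1=C(O)[C@H]3CCCC[C@H]3N(Cc3ccc(F)cc3)C1=O)N2`. In this assay compound 2 gives > 1000 nM, again only a limit.
Compound 3 `CC(C)(C)CCN1C(=O)C(C2=NS(=O)(=O)c3cc(NS(C)(=O)=O)ccc3N2)=C(O)C2CCCCCC21`. In this assay compound 3 gives > 10000 nM, also a limit.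

Compound 2 thus stands at a limit, with no number of its own; the two other values shown are limits as well, so no order among the three compounds can be read. Within the data shown here, the one measured step that touches compound 2 is a step that the two limits leave unreadable from compound 1 to compound 2, which stays unreadable because the limit of > 33000 nM in this assay, at which 1 of the 3 values shown sits, and the limit of > 1000 nM in this assay, at which 1 of the 3 values shown sits, are both limits; its structural basis is the fact that one of compounds 1 and 2 is drawn with a defined configuration and the other without, at the place where they differ. Among the measured compounds shown here, compound 3 has no step to compound 2, and its value shows only another limit.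

Compound 4 `CS(=O)(=O)Nc1ccc2c(c1)S(=O)(=O)N=C(C1=C(O)[C@@H]3CCCC[C@@H]3N(Cc3ccc(F)cc3)C1=O)N2` is the target. Against compound 2 the change is the two compounds have the same atoms and bonds and differ only in configuration as drawn: 2 of 2 stereo elements differ (all stereocentres are inverted: mirror images); a stereocentre at a saturated ring carbon is drawn S in compound 2 and R in compound 4; a stereocentre at a saturated ring carbon is drawn R in compound 2 and S in compound 4. With no readable step in hand, the expectation for this assay is a step from compound 2 to compound 4 of a step that the limit leaves unreadable from compound 2 to compound 4, within the scatter, most likely reported again as a limit. Compound 4 is therefore estimated at 33000 nM, between 10000 nM and 100000 nM.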

Compound 4, half-maximal cytotoxic concentration: > 33000 nM
Compound 4: only a limit was reported; the forecaster's own chance of this, stated with the estimate: 85%; the middle value lies on the limit itself.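

In this assay, among these compounds, compound 4 gives > 33000 nM, a limit and not a number, so no step among compound 1, compound 2 and compound 4 can be read. The compounds shown leave open whether the mirror images compound 2 and compound 4 differ in cytotoxicity, and at what concentration any compound shown becomes cytotoxic.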